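Isoxazole amide replacing chloromethylphenyl on inactive series

The source may report more compounds than this note shows. Statements on the series, on what has been measured and on what is new or still open speak of the compounds shown alone.

Working notes on the series. In a functional assay on HeLa cells (Homo sapiens) for antiproliferative activity, read by MTT assay, with a stated time of 72 h (a lower number here means a stronger inhibitor, a higher number a weaker inhibitor), compound 1 `CS(=O)(=O)c1ccc(C(=O)Nc2ccc(Cl)c(-c3nnc4c(Cl)cccn34)c2)cc1` reports only the assay limit, > 100000 nM. Compound 2 `Cc1cc(Cl)ccc1C(=O)Nc1ccc(Cl)c(-c2nnc3c(Cl)cccn23)c1` likewise reports only the assay limit, > 100000 nM. The step from compound 1 to compound 2, a step that the two limits leave unreadable from compound 1 to compound 2, is therefore unreadable; both sit at the limit of > 100000 nM in this assay, at which 2 of the 2 values shown sit. Compound 3 `O=C(Nc1ccc(Cl)c(-c2nnc3c(Cl)cccn23)c1)c1ccon1` carries 1,2-oxazol-3-yl in place of 4-chloro-2-methylphenyl on a carbonyl carbon. No measured step bears on this change, and nothing shown gives a direction. Compound 3 is expected to stay at the limit, estimated at 100000 nM (range 20000 nM to 300000 nM). The expected step is a number no higher from compound 2 to compound 3 (the limit leaves the size open).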

Compound 3, half-maximal inhibitory concentration: > 100000 nM
Compound 3 gave a limit, no number; the forecaster's own chance of this, stated with the estimate: 80%; the middle value lies on the limit itself.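

No step can be read among compound 1, compound 2 and compound 3, since each reports only a limit: the limit of > 100000 nM in this assay, at which 3 of the 3 values shown sit.

The compounds shown leave open how the 4-(methylsulfonyl)phenyl, 4-chloro-2-methylphenyl and 1,2-oxazol-3-yl groups rank, and whether any group on this carbonyl carbon gives a readable value.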